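Trimming the terminal amine on a shared side chain

The source may report more compounds than this note shows. Statements on the series, on what has been measured and on what is new or still open speak of the compounds shown alone.

Three compounds share one core and differ only in the group on an oxygen on an aromatic ring. Compound 1 `COc1cc(OC)c2c(=O)cc(-c3ccc(OC4CCN(C)CC4)cc3)oc2c1` carries 1-methylpiperidin-4-yl there, and in a functional assay (Homo sapiens) for antiproliferative activity, read by resazurin assay, with a stated time of 48 h, tested at 10 uM (a higher number here means a stronger effect of the compound at the concentration tested, a lower number a weaker effect), compound 1 gives 49%. Compound 2 `COc1cc(OC)c2c(=O)cc(-c3ccc(OCCCN)cc3)oc2c1` carries 3-aminopropyl, and in this assay compound 2 gives 39%. Compound 3 `COc1cc(OC)c2c(=O)cc(-c3ccc(OCC(O)CN4CCCC4)cc3)oc2c1` carries 2-hydroxy-3-(pyrrolidin-1-yl)propyl, and in this assay compound 3 gives 37%. Compound 3 stands lowest of the three numbers shown: the step of a number 2 percentage points lower from compound 2 to compound 3 (within the scatter) lies within the scatter, while the step of a number 12 percentage points lower from compound 1 to compound 3 (beyond the scatter) lies beyond it. The step of a number 10 percentage points lower from compound 1 to compound 2 (within the scatter) is also within the scatter.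

Compound 4 `COc1cc(OC)c2c(=O)cc(-c3ccc(OCC(O)CN(C)C)cc3)oc2c1` differs from compound 3 in one place: dimethylamino in place of pyrrolidin-1-yl on a saturated chain carbon, two bonds along the chain from an oxygen on a saturated carbon. Among the compounds with values here, no measured step exchanges the amine end of the chain in exactly this way. The nearest comparison is the step of a number 2 percentage points lower from compound 2 to compound 3 (within the scatter), which replaced one amine end by another and stayed within the scatter, and the step of a number 10 percentage points lower from compound 1 to compound 2 (within the scatter), which likewise stayed within it. On that basis no step beyond the scatter is expected, and the expected step of no change at the digits printed from compound 3 to compound 4 (within the scatter) is small. Compound 4 is therefore estimated at 37%, within a range from 25% to 50%.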

Compound 4, a percentage reported as inhibition, at one concentration (the size of the read-out at that concentration, not a potency): 60%
Beside the measured number, compound 4's estimate is 23 percentage points below it; the whole stated range lies below it.
By their numbers in this assay, from the lowest: compounds 3, 2 and 1 (each within the scatter of the next, the first and the last beyond it); then compound 4.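

In this assay, the amine end of the 2-hydroxypropyl chain proves to be a sensitive point: dimethylamino in place of pyrrolidin-1-yl gives a number 23 percentage points higher from compound 3 to compound 4 (beyond the scatter), the first step among these compounds to follow a change at the far end of that chain alone, and it takes the open amine with 3 heavy atoms well clear of the ring amine with 5. The same chain no longer sits at the low end of the set, since the comparisons show a number 21 percentage points higher from compound 2 to compound 4 (beyond the scatter) and a number 11 percentage points higher from compound 1 to compound 4 (beyond the scatter), which places compound 4 highest of the four and shows that the side chain as a whole does not fix the read-out. Nothing measured here bears on why this exchange has such an effect.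

From the compounds shown here alone, whether the ring itself or only the size of the amine end governs the result remains open, and diethylamino, piperidin-1-yl or morpholin-4-yl on the same chain would separate those readings. Also open, going by these compounds, is what the chain hydroxyl contributes, which a 3-(dimethylamino)propyl chain without it would test.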